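Swapping the chlorophenyl group on a methylated growth inhibitor

A few compounds are considered here, and "the series" means these few. Any claim that something is new, unique, unknown or untested is made for them only; others in the source may bear on it.

Compounds in a functional assay on A2780 cells (Homo sapiens) for inhibition, read by sulforhodamine B assay; on this read-out lower numbers stand for stronger inhibition of growth and higher numbers for weaker inhibition of growth:
Compound 1 `Cc1ccc2[nH]c(-c3ccc(-c4ccc(-c5cccc(Cl)c5)cc4)cc3)nc2c1`: 2800 nM
Compound 2 `Clc1cccc(-c2ccc(-c3ccc(-c4nc5ccccc5[nH]4)cc3)cc2)c1`: 31100 nM
Compound 3 `Oc1cccc2[nH]c(-c3ccc(-c4ccc(-c5ccc(F)cc5)cc4)cc3)nc12`: 41200 nM
Compound 4 `Cc1ccc2[nH]c(-c3ccc(-c4ccc(-c5ccc(O)cc5)cc4)cc3)nc2c1`: not yet measured

Of the three measured compounds, compound 1 gives the lowest number in this assay, and the values of the other two lie beyond the scatter from it. Compound 4 differs from compound 1 in a single place: 4-hydroxyphenyl in place of 3-chlorophenyl on an aromatic carbon. In words, 4-hydroxyphenyl stands in place of 3-chlorophenyl on an aromatic carbon, para to a large group.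

Going by the values given here, no measured step covers this exchange. Among the compounds with values here, the only single-place step is an 11-fold higher number from compound 1 to compound 2 (1.05 log units; beyond the scatter), where hydrogen replaces methyl on an aromatic carbon. That step is large, but it lies elsewhere in the structure, and compound 4 keeps the methyl group. Within the data shown here, it shows only that one small change can move the number considerably in this set. A moderate rise, smaller than that step, is therefore expected, though a result close to compound 1 would be no surprise. The expected change is a 1.8-fold higher number from compound 1 to compound 4 (0.25 log units; within the scatter). For compound 4 the estimated value is 5000 nM, with an expected range of 1000 nM to 25000 nM.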

Compound 4, concentration for 50% growth inhibition: 31200 nM
The estimate for compound 4 lay 6.2-fold (0.80 log units) below the measured number, and the stated range ends below it.
By their numbers in this assay, from the lowest: compound 1; then compounds 2, 4 and 3 (each within the scatter of the next).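

In this assay, going by these compounds alone, the exchange of 3-chlorophenyl for 4-hydroxyphenyl gives an 11-fold higher number from compound 1 to compound 4 (1.05 log units; beyond the scatter) and so shows that this end of the molecule, which no earlier single-place step had touched, is not indifferent to what it carries. With the methyl group kept, this one exchange moves the number as far as the removal of that methyl group does in an 11-fold higher number from compound 1 to compound 2 (1.05 log units; beyond the scatter) and thus the low number of compound 1 depends on both places, not on the methyl group alone. Nothing in the material shown accounts for the size of this rise.

The exchange changes both the substituent, chlorine giving way to hydroxyl, and its place on the ring, and the compounds shown do not separate these two changes, since neither 3-hydroxyphenyl nor 4-chlorophenyl stands among them on this core. As far as these compounds go, it also stays open whether a methoxy group, an amine or a carboxylic acid on this ring would keep the number close to that of compound 1 or raise it as hydroxyl does.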